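The source may report more compounds than this note shows. Statements on the series, on what has been measured and on what is new or still open speak of the compounds shown alone.

In a functional assay on KYSE-70 cells for antiproliferative activity against KYSE-70 cell line (Homo sapiens), read by MTT assay, with a stated time of 72 h (on this read-out lower numbers stand for stronger inhibition and higher numbers for weaker inhibition), three compounds have been measured so far. Compound 1 `COc1ccccc1NC(=O)c1ccnc2cc(Br)ccc12` gives > 20000 nM, which is a limit of the assay and not a number. Compound 2 `O=C(Nc1cc(F)cc(F)c1)c1cc(=O)[nH]c2cc(Cl)ccc12` gives 9000 nM. Compound 3 `O=C(Nc1cccc(F)c1)c1cc(=O)[nH]c2cc(-c3ccsc3)ccc12` gives 5100 nM. The numbers for compound 2 and compound 3 lie within the usual scatter of each other, so compound 3 stands level with compound 2, and no order can be read between them.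

The next compound, compound 4 `O=C(Nc1cccc(F)c1)c1cc(=O)[nH]c2cc(-c3ccc(F)nc3)ccc12`, keeps the core of compound 3 and changes one group: 6-fluoropyridin-3-yl in place of thiophen-3-yl on an aromatic carbon, (6-fluoropyridin-3-yl in place of thiophen-3-yl on an aromatic carbon). Going by the values given here, no two measured compounds differ in one place only, so the data do not show directly what such a swap does. The expected outcome in this assay is therefore no step beyond the scatter, in either direction. The estimated change a 1.1-fold lower number from compound 3 to compound 4 (0.05 log units; within the scatter) is correspondingly small. For compound 4 the estimated value is 4500 nM, with an expected range of 1500 nM to 13000 nM.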

Compound 4, half-maximal inhibitory concentration: > 20000 nM
Compound 4: a limit, no number; the forecaster's own chance of this, stated with the estimate: 7%; at least 4.4-fold (0.64 log units) between middle value and limit.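

The swap of thiophen-3-yl for 6-fluoropyridin-3-yl on this aromatic carbon is the first change in one place among the compounds shown, and in this assay it is not neutral: it gives an at least 3.9-fold higher number from compound 3 to compound 4 (0.59 log units; beyond the scatter). Compound 4 reads > 20000 nM, which is a limit of the assay and not a number, so this step shows only a smallest size and the full size cannot be read: the limit of > 20000 nM in this assay, at which 2 of the 4 values shown sit. This position therefore does not accept every aromatic ring alike, since one ring here leaves a measurable value and the other does not.

Going by these compounds, the two rings differ at once in ring size, in hetero atom and in the fluorine, so the change that matters stays open. A pyridin-3-yl without fluorine, a plain phenyl or a small amine at this position would help to separate these.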